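Working notes: expected value for compound 4

A few compounds are considered here, and "the series" means these few. Any claim that something is new, unique, unknown or untested is made for them only; others in the source may bear on it.

Measured so far:
Compound 1 `Fc1ccc(Cn2cc(CSC(=S)N3CCNCC3)nn2)cc1` gives a limit of the assay, > 128000 nM.
Compound 2 `O=C(OCc1ccccc1)N1CCN(C(=S)SCc2cn(Cc3ccc(F)cc3)nn2)CC1` gives 32000 nM.
Compound 3 `CC(C)(C)OC(=O)N1CCN(C(=S)SCc2cn(Cc3ccc(Cl)cc3)nn2)CC1` gives a limit of the assay, > 128000 nM.
Compound 4 `O=C(OCc1ccccc1)N1CCN(C(=S)SCc2cn(Cc3ccccc3Cl)nn2)CC1` is not yet measured.

For the measured compounds named here, in a functional assay on ECa-109 cells (Homo sapiens) for inhibition, read by MTT assay, with a stated time of 72 h (a higher number here means a weaker inhibitor, a lower number a stronger inhibitor), compound 2 holds the only real number among the three measured compounds; the other two sit at the limit of > 128000 nM in this assay, at which 2 of the 3 values shown sit. Going by the values given here, the one step with both ends known is an at least 4.0-fold lower number from compound 1 to compound 2 (0.60 log units; beyond the scatter), and it concerns the carbamate on the ring nitrogen, not the halophenyl. Compound 4 differs from compound 2 by 2-chlorophenyl in place of 4-fluorophenyl on a saturated chain carbon bound to an aromatic nitrogen. Among the compounds with values here, no measured step alters that group alone: compound 3 differs from compound 2 in two places at once, and its limit says nothing more than that. The expected change is therefore small, within the scatter, with a 1.3-fold higher number from compound 2 to compound 4 (0.10 log units; within the scatter) as the working estimate. Compound 4 is expected to give 40000 nM in this assay, with a range from 14000 nM to 115000 nM.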

Compound 4, half-maximal inhibitory concentration: 56800 nM
The estimate for compound 4 lay 1.4-fold (0.15 log units) below the measured number; low and high end bracket the measured number.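

In this assay, for the compounds shown here, 2-chlorophenyl in place of 4-fluorophenyl on a saturated chain carbon bound to an aromatic nitrogen gives a 1.8-fold higher number from compound 2 to compound 4 (0.25 log units; within the scatter), the first step that can be read at this place. With benzyloxycarbonyl held constant on the ring nitrogen, the 4-fluorobenzyl and 2-chlorobenzyl groups are not told apart in this assay. The halogen and its ring position change together in this one step, so neither can be read alone.

Compound 3 is a limit of the assay and differs from compound 2 in two places, so it cannot be read for this position: the limit of > 128000 nM in this assay, at which 2 of the 4 values shown sit.
From the compounds shown here alone, whether an unsubstituted benzyl group, a longer chain or a carboxylic acid at this place would stay within the scatter of compound 2 remains open.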